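This account rests on a few compounds, and the source may have more. Where it says the series, first, only, none or still open, it means among the compounds named here.

In a functional assay on HCT-116 cells (Homo sapiens) for antiproliferative activity, read by MTT assay, with a stated time of 48 h (on this read-out lower numbers stand for stronger inhibition and higher numbers for weaker inhibition), compound 3 `CC(=O)Nc1ccc(-n2nncc2CN2C(=O)C3(C(C#N)=C(N)Oc4c3c3nc5ccccc5nc3c3ccccc43)c3ccccc32)cc1` sits only at a limit of the assay, not at a number: compound 3 gives > 50000 nM, which is a limit. The two compounds that stand beside it are in the same position. Compound 1 `N#CC1=C(N)Oc2c(c3nc4ccccc4nc3c3ccccc23)C12C(=O)N(Cc1cnnn1-c1ccc(F)cc1)c1ccccc12` gives > 50000 nM, a limit. Compound 2 `N#CC1=C(N)Oc2c(c3nc4ccccc4nc3c3ccccc23)C12C(=O)N(Cc1cnnn1-c1ccccc1Cl)c1ccccc12` gives > 50000 nM, also a limit. The steps among these three are therefore not readable in size: from compound 1 to compound 2 the step is a step that the two limits leave unreadable from compound 1 to compound 2, from compound 1 to compound 3 it is a step that the two limits leave unreadable from compound 1 to compound 3, and from compound 2 to compound 3 it is a step that the two limits leave unreadable from compound 2 to compound 3. All three values rest at the limit of > 50000 nM in this assay, at which 3 of the 3 values shown sit.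

Compound 4 `N#CC1=C(N)Oc2c(c3nc4ccccc4nc3c3ccccc23)C12C(=O)N(Cc1cnnn1-c1ccc(F)c(Cl)c1)c1ccccc12` differs from compound 3 by 3-chloro-4-fluorophenyl in place of 4-acetamidophenyl on an aromatic nitrogen. The change bearing on it is a halophenyl on the aromatic nitrogen in place of the 4-acetamidophenyl, and compounds 1 and 2, which carry a halophenyl there, both sit at the limit. Among the measured compounds shown here, no step of readable size exists, so nothing beyond the scatter can be expected in this assay. Compound 4 is therefore expected to remain at the limit, with an estimated step that the limit leaves unreadable from compound 3 to compound 4 and an estimated value of 60000 nM, between 20000 nM and 200000 nM.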

Compound 4, half-maximal inhibitory concentration: > 50000 nM
Compound 4: only a limit was reported; the forecaster's own chance of this, stated with the estimate: 85%; the middle value is on the limit's open side.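

Compound 4 also rests at a limit, so the steps joining it to compounds 1, 2 and 3 cannot be read in this assay: the limit of > 50000 nM in this assay, at which 4 of the 4 values shown sit.

The compounds shown leave open how far apart these four actually lie, and whether any group on the aromatic nitrogen would give a measurable value.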